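A Bromine Added to the Ethyl Chain

The source may hold more compounds than are shown below. What is called first, only, known or untested is meant among the compounds shown, and "the series" means these compounds.

Of the compounds shown here, three have so far been tested in a functional assay on A549 cells (Homo sapiens) for antiproliferative activity, read by sulforhodamine B assay, with a stated time of 72 h; on this read-out higher numbers stand for weaker inhibition of growth and lower numbers for stronger inhibition of growth. Among the compounds with values here, compound 1 `Cc1cc(=O)oc2cc(SCc3cccc(OC(F)(F)F)c3)ccc12` is the only one that yields a number: in this assay compound 1 gives 17400 nM. Compound 2 `CCc1cc(=O)c2ccc(OC(C)C)c(CBr)c2o1` reaches only a limit of the assay, > 30700 nM. Compound 3 `CCc1cc(=O)c2ccc(OCC(C)C)c(CBr)c2o1` also reaches only a limit, > 29400 nM. Compound 2 sits at the limit of > 30700 nM in this assay, at which 1 of the 3 values shown sits. Compound 3 sits at the limit of > 29400 nM in this assay, at which 1 of the 3 values shown sits. Within the data shown here, the one step between measured neighbours, a step that the two limits leave unreadable from compound 2 to compound 3, therefore cannot be read in size or direction. Compound 3 thus stands among the values as a limit, with one further value also a limit and a single true number from compound 1.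

Compound 4 `CC(C)COc1ccc2c(=O)cc(C(C)Br)oc2c1CBr` differs from compound 3 by bromo in place of hydrogen on a saturated chain carbon bound to an aromatic carbon and a saturated chain carbon. Among the measured compounds shown here, no measured step touches this position, and the only step available is unreadable, so the measured data give no size and no direction for the change. The expected step that the limit leaves unreadable from compound 3 to compound 4 is taken as none beyond the scatter, resting on the limit shown for compound 3, > 29400 nM. Compound 4 is therefore expected to give about 30000 nM in this assay, with a range from 8000 nM to 100000 nM, and a good chance that only a limit is reported again.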

Compound 4, concentration for 50% growth inhibition: 8710 nM
Compound 4: the middle estimate sits 3.4-fold (0.54 log units) above what was measured, and the stated range covers the measured number.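

In this assay, putting bromo in place of hydrogen on a saturated chain carbon bound to an aromatic carbon and a saturated chain carbon, which turns ethyl into 1-bromoethyl, gives an at least 3.3-fold lower number from compound 3 to compound 4 (0.52 log units; beyond the scatter). This is the first readable step among these compounds, and it shows that a change at this spot on the chain can move growth inhibition by more than the usual scatter, whereas the earlier pair, which differs in its group on oxygen, gave no step that can be read. The step is a minimum and the true change could be larger, since compound 3 reaches only a limit of the assay: the limit of > 29400 nM in this assay, at which 1 of the 4 values shown sits.

A single replacement at this position cannot show whether bromo itself matters or whether another group on the same carbon, such as chloro, hydroxyl or an amine, would serve as well. On these data alone, it also stays open whether a longer chain carrying the bromine, such as 1-bromopropyl, would give a lower or a higher number, and whether isobutyl and isopropyl on the oxygen differ once the 1-bromoethyl group is present.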